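The source may hold more compounds than are shown below. What is called first, only, known or untested is meant among the compounds shown, and "the series" means these compounds.

Measured so far in an assay on HeLa cells for inhibition of Kinesin-like protein KIF15 (Homo sapiens), read by microscopy, with stated times of 2 s and 20 s, tested at 750 nM; on this read-out higher numbers stand for more inhibition at the one concentration tested (going by the name of the read-out) and lower numbers for less inhibition:
compound 1 `O=C1Nc2ccc(C(=O)c3ccco3)cc2/C1=C/c1cc(I)c(O)c(I)c1` gives 26%
compound 2 `O=C1Nc2ccc(C(=O)c3ccco3)cc2/C1=C/c1cc(F)c(O)c(Br)c1` gives 38%
compound 3 `O=C1Nc2ccc(C(=O)c3ccco3)cc2/C1=C/c1cc(Cl)c(O)c(Br)c1` gives 62%

Compound 3 stands highest of the three: the step of a number 36 percentage points higher from compound 1 to compound 3 (beyond the scatter) is large, the step of a number 24 percentage points higher from compound 2 to compound 3 (beyond the scatter) is modest, and the step of a number 12 percentage points higher from compound 1 to compound 2 (beyond the scatter) is modest, so the ordering on this assay is clear throughout.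

Compound 4 `O=C1Nc2ccc(C(=O)c3ccco3)cc2/C1=C/c1cc(Br)cc(Br)c1` differs from compound 3 as follows: a group of 8 heavy atoms (6 carbon, 2 bromine; one six-membered aromatic ring of carbon only) in place of a group of 9 heavy atoms (6 carbon, 1 oxygen, 1 chlorine, 1 bromine; one six-membered aromatic ring of carbon only), on a double-bonded chain carbon bound to a double-bonded ring carbon

Among the measured compounds shown here, the measured steps all exchange halogens on a ring that keeps its hydroxyl; the hydroxyl is never removed in the measured set, so no step bears directly on the change to compound 4. The halogen steps show that the ring substitution pattern moves this read-out by modest to large amounts, and the entering 3,5-dibromophenyl carries no hydrogen-bond donor or acceptor where the leaving group has one of each. A loss against compound 3 is expected, of uncertain size.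

The expected step is a number 24 percentage points lower from compound 3 to compound 4 (beyond the scatter). Compound 4 is estimated at 38%, with a range of 12% to 64%.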

Compound 4, a percentage reported as inhibition, at one concentration (the size of the read-out at that concentration, not a potency): 16%
Compound 4: middle estimate off by 22 percentage points, on the high side; the range from low to high includes it.
By their numbers in this assay, from the lowest: compounds 4 and 1 (each within the scatter of the next); then compound 2; then compound 3.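

In this assay, 3,5-dibromophenyl on the double-bonded chain carbon reads well under both hydroxylated bromo groups (a number 46 percentage points lower from compound 3 to compound 4 (beyond the scatter)) and (a number 22 percentage points lower from compound 2 to compound 4 (beyond the scatter)), so a hydroxyl-free group has now been tested at this position and the larger step is as large as any among the halogen exchanges. Compound 1 goes against any simple rule that the hydroxylated group wins: the step to 3,5-dibromophenyl (a number 10 percentage points lower from compound 1 to compound 4 (within the scatter)) lies within the scatter, so keeping the hydroxyl does not by itself give a higher number. No measured evidence accounts for these steps.

As far as these compounds go, every step to compound 4 changes the hydroxyl and the halogens together, so the share of each stays open. From the compounds shown here alone, how an amine or a carboxylic acid in place of the hydroxyl would read also stays open.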